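A few compounds are considered here, and "the series" means these few. Any claim that something is new, unique, unknown or untested is made for them only; others in the source may bear on it.

Compound 1 `Cc1cc(NC(=O)c2cc(C(F)(F)F)cc(C(F)(F)F)c2)ccc1NS(=O)(=O)C(F)(F)F`: 182000 nM
Compound 2 `COc1cc(NC(=O)c2cc(C(F)(F)F)cc(C(F)(F)F)c2)ccc1NS(C)(=O)=O`: 42000 nM
Compound 3 `COc1cc(NC(=O)c2cccc(C(F)(F)F)c2)ccc1NS(=O)(=O)C(F)(F)F`: > 250000 nM

In an ADME assay on HEK293 cells (Homo sapiens) for cytotoxicity, read by MTT assay, with a stated time of 48 h (a lower number here means a stronger inhibitor, a higher number a weaker inhibitor), compound 3 gives no number, only a limit, and so stands at the limit of > 250000 nM in this assay, at which 1 of the 3 values shown sits. Compound 1 and compound 2 each give a measured value in this assay, with compound 2 at 42000 nM. Compound 4 `COc1cc(NC(=O)c2cc(C(F)(F)F)cc(C(F)(F)F)c2)ccc1NS(=O)(=O)C(F)(F)F` differs from compound 3 by trifluoromethyl in place of hydrogen on an aromatic carbon, and so carries the same bis-trifluoromethyl benzamide as compound 1 and compound 2. Among the measured compounds shown here, as no step between measured compounds is known, the direction rests on those two: compound 4 is expected to give a number in this assay rather than a limit, the step of an at least 2.5-fold lower number from compound 3 to compound 4 (0.39 log units; beyond the scatter) pointing toward a lower value. Compound 4 is estimated at 100000 nM, between 30000 nM and 250000 nM.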

Compound 4, half-maximal inhibitory concentration: > 250000 nM
Compound 4: only a limit was reported; the forecaster's own chance of this, stated with the estimate: 25%; middle value at least 2.5-fold (0.39 log units) away from the limit.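

In this assay, trifluoromethyl in place of methyl on a sulfonyl sulfur gives an at least 5.9-fold higher number from compound 2 to compound 4 (0.77 log units; beyond the scatter), the first readable effect of a change at that position. Methoxy in place of methyl on an aromatic carbon gives an at least 1.3-fold higher number from compound 1 to compound 4 (0.13 log units; that floor lies within the scatter), so no clear effect of that change is shown. The step for trifluoromethyl in place of hydrogen on an aromatic carbon cannot be read, as compound 3 and compound 4 both stand at a limit: the limit of > 250000 nM in this assay, at which 2 of the 4 values shown sit.

Going by these compounds, how an amine or a longer chain on the sulfonyl sulfur would read in this assay stays open. Any order between compound 3 and compound 4 also stays open.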